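Swapping One Aromatic Group on a Saturated Ring Carbon

The source may hold more compounds than are shown below. What is called first, only, known or untested is meant among the compounds shown, and "the series" means these compounds.

In an ADME assay on the whole organism (Mus musculus, strain ICR) for pharmacokinetics, at a dose of 50 mg/kg by the oral route (on this read-out lower numbers stand for lower exposure and higher numbers for higher exposure at the dose given), compound 1 `O=C1CC(Oc2ncccn2)CN1c1cnn2c1CN(C(=O)Nc1cc(F)c(F)c(F)c1)C(C1CC1)C2` gives 4020 ng.h/mL and compound 2 `O=C1CC(c2ncccn2)CN1c1cnn2c1CN(C(=O)Nc1cc(F)c(F)c(F)c1)C(C1CC1)C2` gives 5070 ng.h/mL, so with only these two numbers compound 1 cannot be separated from its neighbour. The next compound to be measured is compound 3 `Cc1nc(C2CC(=O)N(c3cnn4c3CN(C(=O)Nc3cc(F)c(F)c(F)c3)C(C3CC3)C4)C2)no1`, and it differs from compound 1 as follows: 5-methyl-1,2,4-oxadiazol-3-yl in place of (pyrimidin-2-yl)oxy on a saturated ring carbon. Put simply, 5-methyl-1,2,4-oxadiazol-3-yl takes the place of (pyrimidin-2-yl)oxy on a saturated ring carbon, while the rest of the molecule stays the same.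

Within the data shown here, one measured step bears on this change, since it replaced the same group at the same carbon with pyrimidin-2-yl and gave a 1.3-fold higher number from compound 1 to compound 2 (0.10 log units; within the scatter). Among the measured compounds shown here, that step stayed within the scatter, but it is only a single example, and no measurement yet shows a five-membered aromatic ring at this carbon. A step beyond the scatter is therefore not expected, and the expected step is a 1.1-fold higher number from compound 1 to compound 3 (0.05 log units; within the scatter). The estimate for compound 3 is 4500 ng.h/mL, with an expected range from 2000 ng.h/mL to 10000 ng.h/mL.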

Compound 3, area under the concentration-time curve: 3860 ng.h/mL
Estimate against measurement, compound 3: 1.2-fold (0.07 log units) above; the range from low to high includes it.
By their numbers in this assay, from the lowest: compounds 3, 1 and 2 (each within the scatter of the next).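

In this assay, a five-membered aromatic ring at this saturated ring carbon gives a 1.0-fold lower number from compound 1 to compound 3 (0.02 log units; within the scatter) and, set against the directly attached pyrimidin-2-yl, gives a 1.3-fold lower number from compound 2 to compound 3 (0.12 log units; within the scatter) as well. The position therefore tolerates more than one kind of group here: a six-membered ring with or without the linking oxygen and a five-membered ring with 3 hetero atoms all give values within the scatter of one another, so oral exposure in this assay does not separate these three groups. Nothing measured here indicates what lies behind this similarity.

From the compounds shown here alone, all three groups are aromatic rings with no net charge, so it remains open whether an amine, a carboxylic acid or a longer alkyl chain on this carbon would keep the exposure in the same range. Also open, going by these compounds, is whether the same similarity would appear with a different core, since all three compounds share the core of compound 1 and are compared at a single oral dose in one mouse strain.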